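A few compounds are considered here, and "the series" means these few. Any claim that something is new, unique, unknown or untested is made for them only; others in the source may bear on it.

Measured so far in a functional assay on KB cells (Homo sapiens) for antiproliferative activity, read by sulforhodamine B assay, with a stated time of 48 h; a higher number here means a weaker inhibitor of growth, a lower number a stronger inhibitor of growth:

Compound 1 `CCCNc1nc(Nc2ccc(OC)cc2)nc2ccccc12`: 5330 nM
Compound 2 `OCCCNc1nc(Nc2ccc(F)cc2)nc2ccccc12`: 17100 nM

Of these two, compound 2 has the higher number at 17100 nM, which makes it the weaker inhibitor of growth, and its gap to compound 1 lies beyond the usual scatter. The two differ in more than one place, so that gap cannot be pinned on any single group.

Compound 3 `CCCNc1nc(Nc2ccc(F)cc2)nc2ccccc12` has not yet been measured. It departs from compound 2 in one place only: hydrogen in place of hydroxy on a saturated chain carbon, three bonds along the chain from a nitrogen on an aromatic ring. In words, hydrogen stands in place of hydroxy on a saturated chain carbon, three bonds along the chain from a nitrogen on an aromatic ring, so 3-hydroxypropyl becomes propyl.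

For the measured compounds named here, no measured pair shows this change alone in this assay. Going by the values given here, the only hint is that compound 1, which carries the propyl chain, gives 5330 nM. A modest fall in the number is therefore expected, though a step within the scatter remains possible. The estimated change is a 2.1-fold lower number from compound 2 to compound 3 (0.33 log units; beyond the scatter). For compound 3 the expected value is 8000 nM, with an estimated range of 3000 nM to 18000 nM.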

Compound 3, concentration for 50% growth inhibition: 2900 nM
The estimate for compound 3 lay 2.8-fold (0.44 log units) above the measured number; the whole stated range lies above it.
By their numbers in this assay, from the lowest: compounds 3 and 1 (each within the scatter of the next); then compound 2.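

In this assay, hydrogen in place of hydroxy gives a 5.9-fold lower number from compound 2 to compound 3 (0.77 log units; beyond the scatter). For the compounds shown here, this is the first clean reading of this change: with the fluoro group held fixed, 3-hydroxypropyl gives a clearly weaker inhibitor of growth than propyl, and the step is beyond the scatter. The aromatic group can now be read on its own too, since with the propyl chain held fixed, fluoro in place of methoxy gives a 1.8-fold lower number from compound 1 to compound 3 (0.26 log units; within the scatter), a step within the scatter, so these two groups cannot be told apart in this assay, and nothing on hand explains what lies behind either step.

The compounds shown leave open whether hydroxy is a special case on this saturated chain carbon or whether another end group, such as an amine or a carboxylic acid, would give a similar step. They also do not show whether the hydroxy step holds when methoxy replaces fluoro on the aromatic carbon, or how a longer chain, such as butyl, would compare with propyl.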